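Swapping the Ring on the Amide Nitrogen

A few compounds are considered here, and "the series" means these few. Any claim that something is new, unique, unknown or untested is made for them only; others in the source may bear on it.

Compound 1, `O=C(NCCCCc1ccccc1)c1cccc(C2SCC(=O)N2c2cccc(-c3c[nH]nn3)c2)c1`, gives 110 nM in a functional assay on HOS-TE85 cells (Homo sapiens) for inhibition, read by CCK-8 assay, with a stated time of 72 h; a lower number here means a stronger inhibitor, a higher number a weaker inhibitor.
Compound 2, `CC(C)(C)c1conc1N1C(=O)CSC1c1cccc(C(=O)NCCCCc2ccccc2)c1`, gives only a limit of the assay, > 1000 nM.
Compound 3, `O=C(NCCCCc1ccccc1)c1cccc(C2SCC(=O)N2c2ccccn2)c1`, gives 19.7 nM.

Compound 3 holds the lowest of the two numbers shown; compound 1 is its nearest neighbour, and the gap is a 5.6-fold lower number from compound 1 to compound 3 (0.75 log units; beyond the scatter). Compound 2 sits at the limit of > 1000 nM in this assay, at which 1 of the 3 values shown sits.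

Compound 4, `COc1ccc(OC)c(N2C(=O)CSC2c2cccc(C(=O)NCCCCc3ccccc3)c2)c1`, differs from compound 3 by 2,5-dimethoxyphenyl in place of pyridin-2-yl on an amide-type nitrogen in a ring. Every measured step here changes the same group on the amide-type nitrogen in the ring, so all of them bear on this change: a 5.6-fold lower number from compound 1 to compound 3 (0.75 log units; beyond the scatter), an at least 50-fold lower number from compound 2 to compound 3 (1.70 log units; beyond the scatter) and an at least 9.0-fold higher number from compound 1 to compound 2 (0.95 log units; beyond the scatter). Among these three compounds, each group other than pyridin-2-yl went with a higher number, by a modest to a large amount. For compound 4 a higher number is therefore expected, with a modest step of a 5.6-fold higher number from compound 3 to compound 4 (0.75 log units; beyond the scatter). The estimated value for compound 4 is 110 nM, expected to lie between 30 nM and 600 nM.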

Compound 4, half-maximal inhibitory concentration: > 1000 nM
Compound 4 ended at the assay's limit; the forecaster's own chance of this, stated with the estimate: 15%; middle value at least 9.0-fold (0.95 log units) away from the limit.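

In this assay, putting 2,5-dimethoxyphenyl on this amide-type nitrogen goes with an at least 50-fold higher number from compound 3 to compound 4 (1.70 log units; beyond the scatter), and it also goes with an at least 9.0-fold higher number from compound 1 to compound 4 (0.95 log units; beyond the scatter). Compound 1 and compound 4 both carry a six-membered aromatic ring of carbon only at this place, so such a ring does not settle the result by itself, and what else it carries or what stands in its place can count for a great deal. Compound 2 and compound 4 both stand at a limit of the assay, so the step between them cannot be read: the limit of > 1000 nM in this assay, at which 2 of the 4 values shown sit.

On these data alone, what stays open is how a plain phenyl or a pyridin-3-yl group would read at this place. Such groups, or a phenyl with a single methoxy group, could help separate the part played by the ring nitrogen of pyridin-2-yl from that of the two methoxy groups of compound 4.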